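Chlorine on the Benzyl Ring of a Receptor Antagonist

The source may hold more compounds than are shown below. What is called first, only, known or untested is meant among the compounds shown, and "the series" means these compounds.

Compound 1 `COc1ccc(-c2c(CO)n(Cc3ccccc3)c3ccc(OC(F)(F)F)cc23)cn1`: > 10000 nM
Compound 2 `COc1ccc(-c2c(CO)n(Cc3ccc(F)cc3F)c3ccc(OC(F)(F)F)cc23)cn1`: 5110 nM; 5130 nM (2 entries)

Both measured compounds share one core and differ only in the group on the ring nitrogen: compound 1 carries a plain benzyl, compound 2 a fluorinated benzyl. In an assay for antagonist activity at proteinase-activated receptor 4 (Homo sapiens) (on this read-out higher numbers stand for weaker inhibition and lower numbers for stronger inhibition), compound 1 reaches only a limit of the assay, > 10000 nM, not a number. Compound 2 gives 5110 nM; 5130 nM (2 entries) in this assay. Compound 3 `COc1ccc(-c2c(CO)n(Cc3cccc(Cl)c3)c3ccc(OC(F)(F)F)cc23)cn1` differs from compound 1 by chloro in place of hydrogen on an aromatic carbon. Among the measured compounds shown here, no step between measured compounds is at hand, so the expectation rests on the two values alone. Since compound 2 shows that a substituted benzyl can move the value into the measurable range, compound 3 is expected to land near it, with the step of an at least 1.6-fold lower number from compound 1 to compound 3 (0.22 log units; that floor lies within the scatter) expected to be modest and toward stronger inhibition, if beyond the scatter at all. Compound 3 is estimated at 6000 nM, within a range from 2500 nM to 20000 nM.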

Compound 3, half-maximal inhibitory concentration: > 10000 nM
Compound 3: no number, only a limit; the forecaster's own chance of this, stated with the estimate: 35%; at least 1.6-fold (0.22 log units) between middle value and limit.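

In this assay compound 3 gives > 10000 nM, a limit and not a number. Compound 1 gives > 10000 nM, also a limit, so no step can be read between these two compounds. As far as these compounds go, whether chloro in place of hydrogen changes the inhibition at all stays open.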